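Lengthening the diethylamino chain: compound 2 to compound 3

A few compounds are considered here, and "the series" means these few. Any claim that something is new, unique, unknown or untested is made for them only; others in the source may bear on it.

Compound 1 `CN(C)CCn1c(N)c(-c2nc3cc(Cl)ccc3[nH]2)c2nc(C#N)c(C#N)nc21`: 11300 nM
Compound 2 `CCN(CC)CCn1c(N)c(-c2nc3cc(Cl)ccc3[nH]2)c2nc(C#N)c(C#N)nc21`: > 50000 nM

Both values come from a functional assay on K562 cells (Homo sapiens) for antiproliferative activity, read by MTT assay, with a stated time of 48 h; on this read-out higher numbers stand for weaker inhibition and lower numbers for stronger inhibition. Compound 2 has no number here, only (the limit of > 50000 nM in this assay, at which 1 of the 2 values shown sits).

The next change leads to compound 3 `CCN(CC)CCCn1c(N)c(-c2nc3cc(Cl)ccc3[nH]2)c2nc(C#N)c(C#N)nc21`. It is (diethylamino)methyl in place of diethylamino on a saturated chain carbon, two bonds along the chain from an aromatic nitrogen; the same difference reads 2-(diethylamino)ethyl to 3-(diethylamino)propyl.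

Within the data shown here, one measured step bears on this, and only indirectly: an at least 4.4-fold higher number from compound 1 to compound 2 (0.64 log units; beyond the scatter). That step altered the end of the same chain and left its length unchanged, so it gives no direct size for the new change. Compound 2 offers only a limit to start from, so no step beyond the scatter is expected in this assay, and a reported limit would be no surprise. The estimated step is an at least 1.2-fold lower number from compound 2 to compound 3 (0.09 log units; that floor lies within the scatter). Compound 3 is expected at 40000 nM, with an estimated range of 12000 nM to 100000 nM.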

Compound 3, half-maximal inhibitory concentration: 4830 nM
Compound 3: the middle estimate sits 8.3-fold (0.92 log units) above what was measured, outside the stated range (below it).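

Notes on chain length: in this assay, the length of the chain carrying the amine matters at this position, and 3-(diethylamino)propyl in place of 2-(diethylamino)ethyl gives an at least 10-fold lower number from compound 2 to compound 3 (1.01 log units; beyond the scatter). The size of that step is only a floor, as compound 2 has a limit of the assay rather than a number: the limit of > 50000 nM in this assay, at which 1 of the 3 values shown sits. The diethylamino end therefore does not rule out inhibition in this series once it sits on the longer chain, and the comparison with the dimethylamino compound gives a 2.3-fold lower number from compound 1 to compound 3 (0.37 log units; beyond the scatter).

The compounds shown leave open how 3-(dimethylamino)propyl would compare, and so how far chain length alone accounts for this gain. Also open, as far as these compounds go, is whether the trend continues to 4-(diethylamino)butyl or holds with a piperidine at the chain end.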